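Carboxy to chloro on the aryl sulfone of compound 2

This account rests on a few compounds, and the source may have more. Where it says the series, first, only, none or still open, it means among the compounds named here.

In a functional assay on K562 cells (Homo sapiens) for inhibition, read by trypan blue exclusion, with a stated time of 72 h (a lower number here means a stronger inhibitor, a higher number a weaker inhibitor), compound 1 (`COC(=O)Cn1c(=O)c(S(=O)(=O)c2ccc(F)cc2F)cc2cnc(Nc3ccc4[nH]ccc4c3)nc21`) gives 5000 nM and compound 2 (`Cn1c(=O)c(S(=O)(=O)c2ccc(C(=O)O)cc2)cc2cnc(Nc3ccc4[nH]ccc4c3)nc21`) gives 5000 nM. Among the compounds with values here, these two values are level within the scatter and together form the low end of the three numbers so far. Compound 3 (`Cn1c(=O)c(S(=O)(=O)c2ccc(F)cc2F)cc2cnc(Nc3ccc4c(c3)CC(=O)N4)nc21`) gives 15000 nM, a higher number than either, beyond the scatter.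

Compound 4 (`Cn1c(=O)c(S(=O)(=O)c2ccc(Cl)cc2)cc2cnc(Nc3ccc4[nH]ccc4c3)nc21`) departs from compound 2 in one place: chloro in place of carboxy on an aromatic carbon, para to a large group, (chloro in place of carboxy on an aromatic carbon). The same difference reads 4-carboxyphenyl to 4-chlorophenyl.

Within the data shown here, no pair of measured compounds differs in one place only, so this change has no direct precedent. Compound 1 carries no carboxy group and gives 5000 nM, which argues against a large gain. Compound 3 also lacks a carboxy group and gives 15000 nM. Both differ from compound 2 elsewhere too, so neither isolates this change.

A small move toward a stronger inhibitor is expected, estimated as a 2.5-fold lower number from compound 2 to compound 4 (0.40 log units; beyond the scatter). For compound 4 the estimated half-maximal inhibitory concentration is 2000 nM, with an expected range of 500 nM to 8000 nM.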

Compound 4, half-maximal inhibitory concentration: 100 nM
Compound 4: the middle estimate sits 20-fold (1.30 log units) above what was measured; the whole stated range lies above it.
By their numbers in this assay, from the lowest: compound 4; then compounds 1 and 2 (each within the scatter of the next); then compound 3.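

In this assay, within the data shown here, chloro in place of carboxy on the aromatic carbon, para to a large group, gives a 50-fold lower number from compound 2 to compound 4 (1.70 log units; beyond the scatter) and is the first change that can be read in one place. Among these compounds, the group on this carbon therefore has a large bearing on the number, with the rest of compound 2 held constant, something the earlier compounds could not show since each of them differs from the others in more than one place. The count of what changes is plain, with a carboxy group of 3 heavy atoms leaving and a single chlorine entering, but nothing at hand bears on why the step is this large.

Among the compounds shown here, the single step cannot tell whether the gain comes from losing the carboxy group or from gaining chloro, and a bare hydrogen, a methyl, a bromo or a methyl ester on the same carbon would begin to separate those two readings. Going by these compounds, whether a step of this size carries over to other groups on the ring nitrogen or on the amino side of the shared core also stays open.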